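The source may hold more compounds than are shown below. What is called first, only, known or untested is meant among the compounds shown, and "the series" means these compounds.

Measured compounds:
Compound 1, `CC(NC(=O)C1CCN(C(=O)c2cc3ccccc3n2Cc2ccc(Cl)cc2)CC1)c1ccncc1`, gives in an ADME assay on BE(2)-C cells (Homo sapiens) for cytotoxicity, read by MTT assay, with a stated time of 20 h (on this read-out lower numbers stand for higher toxicity in this test and higher numbers for lower toxicity in this test), a value of 90100 nM.
Compound 2, `C[C@@H](NC(=O)C1CCN(C(=O)c2cc3ccccc3n2Cc2ccc(Cl)cc2)CC1)c1ccncc1`, gives in this assay a value of 92300 nM.
Compound 3, `O=C(NCC1COc2cnccc21)C1CCN(C(=O)c2cc3ccccc3n2Cc2ccc(Cl)cc2)CC1`, gives in this assay a value of 75800 nM.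

Compound 2 holds the highest of the three numbers in this assay, but the gaps to its neighbours are small: the step of a 1.0-fold higher number from compound 1 to compound 2 (0.01 log units; within the scatter) and the step of a 1.2-fold lower number from compound 2 to compound 3 (0.09 log units; within the scatter) both lie within the scatter, so the three compounds are indistinguishable on this read-out.

Compound 4, `O=C(NCCn1ccnc1)C1CCN(C(=O)c2cc3ccccc3n2Cc2ccc(Cl)cc2)CC1`, differs from compound 2 by 2-(1H-imidazol-1-yl)ethyl in place of 1-(pyridin-4-yl)ethyl on an amide-type nitrogen. The step that bears on this change is a 1.2-fold lower number from compound 2 to compound 3 (0.09 log units; within the scatter), which also replaced the group on the amide-type nitrogen and stayed within the scatter. The step of a 1.0-fold higher number from compound 1 to compound 2 (0.01 log units; within the scatter) likewise shows no effect of the change at this position. Compound 4 is therefore expected to show a 1.0-fold lower number from compound 2 to compound 4 (0.02 log units; within the scatter), nothing beyond the scatter. Compound 4 is estimated at 88000 nM, in the range 45000 nM to 180000 nM.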

Compound 4, half-maximal cytotoxic concentration: 99600 nM
Compound 4: the middle estimate sits 1.1-fold (0.05 log units) below what was measured, and the stated range covers the measured number.
By their numbers in this assay, from the lowest: compounds 3, 1, 2 and 4 (each within the scatter of the next).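

In this assay, replacing 1-(pyridin-4-yl)ethyl on the amide-type nitrogen with 2-(1H-imidazol-1-yl)ethyl removes the defined stereocentre and the six-membered aromatic ring, yet all three new steps stay within the scatter: a 1.1-fold higher number from compound 2 to compound 4 (0.03 log units; within the scatter) and a 1.1-fold higher number from compound 1 to compound 4 (0.04 log units; within the scatter) and a 1.3-fold higher number from compound 3 to compound 4 (0.12 log units; within the scatter). The earlier compounds shown here carried a six-membered aromatic ring here, so the flat read-out now extends to a five-membered aromatic ring. Nothing available explains this flat read-out.

The compounds shown leave open whether it would hold with a carboxylic acid or a primary amine at this position. They also leave open what a change to the core of compound 1 would do.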